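Pyridin-3-yl in place of 2-hydroxyphenyl on the shared core

A few compounds are considered here, and "the series" means these few. Any claim that something is new, unique, unknown or untested is made for them only; others in the source may bear on it.

Compound 1 `CC(=O)N1N=C(c2ccc3ccccc3c2)OC1c1ccccc1F`: 3.44 ug/mL
Compound 2 `CC(=O)N1N=C(c2ccc3ccccc3c2)OC1c1ccccc1O`: 2.12 ug/mL
Compound 3 `CC(=O)N1N=C(c2ccc3ccccc3c2)OC1c1cccnc1`: not yet measured

In a functional assay on MCF7 cells (Homo sapiens) for antiproliferative activity, read by MTT assay, with a stated time of 48 h (on this read-out higher numbers stand for weaker inhibition and lower numbers for stronger inhibition), compound 2 gives 2.12 ug/mL and compound 1 gives 3.44 ug/mL, so the two stand within the scatter of each other. Compound 3 keeps the core of compound 2 but carries pyridin-3-yl in place of 2-hydroxyphenyl on a saturated ring carbon. Among the compounds with values here, only one measured step bears on this change: a 1.6-fold lower number from compound 1 to compound 2 (0.21 log units; within the scatter), with hydroxy in place of fluoro on an aromatic carbon. Within the data shown here, it stayed within the scatter, and no measured compound carries pyridin-3-yl, so the guidance is thin. No change beyond the scatter is therefore expected in this assay, and any drift would be expected towards a higher number. The expected step is a 1.7-fold higher number from compound 2 to compound 3 (0.22 log units; within the scatter). For compound 3 the estimated value is 3.5 ug/mL, in an expected range of 1.4 ug/mL to 9 ug/mL.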

Compound 3, half-maximal inhibitory concentration: 2.61 ug/mL
Beside the measured number, compound 3's estimate is 1.3-fold (0.13 log units) above it; the range from low to high includes it.
By their numbers in this assay, from the lowest: compounds 2, 3 and 1 (each within the scatter of the next).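

In this assay, pyridin-3-yl on the saturated ring carbon gives a step within the scatter against 2-hydroxyphenyl (a 1.2-fold higher number from compound 2 to compound 3 (0.09 log units; within the scatter)) and against 2-fluorophenyl (a 1.3-fold lower number from compound 1 to compound 3 (0.12 log units; within the scatter)). The earlier pair varied only a substituent on a carbon-only aromatic ring, whereas this result shows that a six-membered aromatic ring with a hetero atom and no hydrogen-bond donor also reads within the scatter at this position. No supporting evidence bears on this result.

All three groups shown at this position are six-membered aromatic rings, so the compounds leave open whether pyridin-2-yl or pyridin-4-yl, or a saturated ring such as piperidin-4-yl, would stay within the scatter. They also leave open what an amine or a carboxylic acid on the aromatic ring would do.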